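From an Amide to a Urea at the Melatonin Receptor

The source may hold more compounds than are shown below. What is called first, only, known or untested is meant among the compounds shown, and "the series" means these compounds.

Among the compounds with values here, compound 1 `CCC(=O)NCC1CCc2c(OC)cccc2N1C` is the only compound here with a number. In a functional assay on CHO cells with melatonin receptor type 1A (Homo sapiens) as the target, read by GTPgammaS binding, with a stated time of 1 h (a lower number here means that less compound is needed, a higher number that more compound is needed for the effect), compound 1 gives 1.7 nM, so little of it is needed for the effect. A second compound, compound 2 `CCC(=O)NCCC1CCc2ccccc2N1Cc1ccccc1`, carries no result in this assay: for compound 2 the entry reads "not determined" (no result reported), so it offers no point of comparison.

The step to compound 3 `CCNC(=O)NCC1CCc2c(OC)cccc2N1C` changes only the group attached to the carbonyl carbon: ethylamino in place of ethyl on a carbonyl carbon. Within the data shown here, no measured pair here shows the effect of such a change, so the size of the step can only be guessed. A modest step is expected, in the direction of more compound being needed, with the step from compound 1 to compound 3 estimated at a 2.9-fold higher number from compound 1 to compound 3 (0.47 log units; beyond the scatter), which may still fall inside the usual scatter. Compound 3 is expected to give about 5 nM in this assay, within a range from 1.5 nM to 20 nM.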

Compound 3, half-maximal effective concentration: 160 nM
Estimate against measurement, compound 3: 32-fold (1.51 log units) below; the whole stated range lies below it.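

At this position, the carbonyl carbon of compound 1, the group is far from interchangeable: in this assay, ethylamino in place of ethyl gives a 94-fold higher number from compound 1 to compound 3 (1.97 log units; beyond the scatter), a large step for what looks like a small edit. Ethylamino brings a nitrogen and a hydrogen-bond donor that ethyl does not have, and the two groups otherwise share the same carbon count, so this single swap is enough to change how much compound is needed. No measurement at hand explains why the step is so large.

The compounds shown do not tell whether the nitrogen alone accounts for the step, which a methoxy or an ethoxy group on the same carbonyl carbon could help to test. They also leave open how a longer chain, such as propylamino or butylamino, would read in this assay.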